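Replacing 4-butoxyphenyl with 3-chlorophenyl in an antiproliferative series

The source may report more compounds than this note shows. Statements on the series, on what has been measured and on what is new or still open speak of the compounds shown alone.

In a functional assay on SGC-7901 cells (Homo sapiens) for antiproliferative activity, read by MTT assay, with a stated time of 24 h (a lower number here means a stronger inhibitor, a higher number a weaker inhibitor), compound 3 `CCCCOc1ccc(C(=O)NNC(=O)c2cccc(NS(=O)(=O)c3cnc(O)nc3O)c2)cc1` gives 7370 nM. Compound 1 `O=C(NNc1cccc(Cl)c1)c1cccc(NS(=O)(=O)c2cnc(O)nc2O)c1` gives 11800 nM, and these two values lie within the scatter of each other. Compound 2 `O=C(NNc1ccccc1F)c1cccc(NS(=O)(=O)c2cnc(O)nc2O)c1` yields no number, only a limit of the assay, > 20000 nM.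

The unmeasured compound 4 `O=C(NNC(=O)c1cccc(NS(=O)(=O)c2cnc(O)nc2O)c1)c1cccc(Cl)c1` keeps the shared core of compound 3 and changes one group: 3-chlorophenyl in place of 4-butoxyphenyl on a carbonyl carbon. In words, 3-chlorophenyl stands in place of 4-butoxyphenyl on a carbonyl carbon.

Among the measured compounds shown here, no measured step makes this exchange. For the measured compounds named here, the only step available is an at least 1.6-fold higher number from compound 1 to compound 2 (0.22 log units; that floor lies within the scatter), where 2-fluorophenyl replaces 3-chlorophenyl on an amine nitrogen. Its floor lies within the scatter, so it sets no firm size for a change of group in this series. The more useful guide is compound 1, which carries 3-chlorophenyl on an amine nitrogen and gives 11800 nM, and a number in that region is expected here. The expected change is modest and towards a higher number, a 1.6-fold higher number from compound 3 to compound 4 (0.21 log units; within the scatter), which would stay within the scatter. For compound 4 the estimated value is 12000 nM, with an expected range from 6000 nM to 20000 nM.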

Compound 4, half-maximal inhibitory concentration: 7310 nM
For compound 4 the middle estimate is 1.6-fold (0.22 log units) above the measured one; low and high end bracket the measured number.
By their numbers in this assay, from the lowest: compounds 4, 3 and 1 (each within the scatter of the next). At a limit, above all of these: compound 2.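

On a carbonyl carbon whose other neighbours are an amide-type nitrogen, the exchange of 4-butoxyphenyl for 3-chlorophenyl gives a 1.0-fold lower number from compound 3 to compound 4 (0.00 log units; within the scatter) in this assay, so within this pair the butoxy chain is not needed to reach this level of activity. The step from the amine-nitrogen series, with (3-chlorophenyl)carbonyl in place of 3-chlorophenyl, gives a 1.6-fold lower number from compound 1 to compound 4 (0.21 log units; within the scatter), which does not separate the two linkages either. With (3-chlorophenyl)carbonyl in place of 2-fluorophenyl on an amine nitrogen, the result is an at least 2.7-fold lower number from compound 2 to compound 4 (0.43 log units; beyond the scatter), the only new step beyond the scatter, though its size is only a floor set by a limit of the assay: the limit of > 20000 nM in this assay, at which 1 of the 4 values shown sits.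

Whether a carboxylic acid, an amine or a longer alkoxy chain on the phenyl ring at this carbonyl carbon would give a value outside the scatter of these compounds remains open. All of these comparisons also rest on the single read-out of this assay, so how far they hold for other cells or other exposure times is not settled by the compounds shown.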